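This account rests on a few compounds, and the source may have more. Where it says the series, first, only, none or still open, it means among the compounds named here.

In a functional assay, read by spectrophotometry, tested at 100 uM (a higher number here means a weaker inhibitor, a lower number a stronger inhibitor), three compounds that share one core and differ in a single group have been measured. Compound 1 `O=C(/C=C/c1ccc(Cl)cc1)c1cccc(NC(=O)c2cc(-c3ccncc3)n[nH]2)c1` gives 78900 nM, compound 2 `O=C(/C=C/c1cccs1)c1cccc(NC(=O)c2cc(-c3ccncc3)n[nH]2)c1` gives 70000 nM, and compound 3 `COc1ccc(/C=C/C(=O)c2cccc(NC(=O)c3cc(-c4ccncc4)n[nH]3)c2)cc1` gives 54600 nM. These numbers all lie within the usual scatter of one another, so compound 3 stands level with the other two, not apart from them.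

The next compound, compound 4 `O=C(/C=C/c1ccco1)c1cccc(NC(=O)c2cc(-c3ccncc3)n[nH]2)c1`, has furan-2-yl in place of 4-methoxyphenyl on a double-bonded chain carbon bound to a double-bonded chain carbon. The measured steps at this same place all bear on the change. They are a 1.1-fold lower number from compound 1 to compound 2 (0.05 log units; within the scatter), a 1.4-fold lower number from compound 1 to compound 3 (0.16 log units; within the scatter) and a 1.3-fold lower number from compound 2 to compound 3 (0.11 log units; within the scatter). None of them goes beyond the scatter, although three compounds are a small sample. Among the measured groups, thiophen-2-yl in compound 2 looks the closest match for furan-2-yl, so the estimate leans a little toward compound 2, which gives 70000 nM.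

No change beyond the scatter is therefore expected in this assay. The expected step is a 1.2-fold higher number from compound 3 to compound 4 (0.08 log units; within the scatter). For compound 4, the estimated value is 65000 nM. The expected range for compound 4 runs from 38000 nM to 105000 nM.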

Compound 4, half-maximal inhibitory concentration: 72300 nM
Estimate against measurement, compound 4: 1.1-fold (0.05 log units) below; the measured number falls inside the stated range.
By their numbers in this assay, from the lowest: compounds 3, 2, 4 and 1 (each within the scatter of the next).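

In this assay, furan-2-yl at this position reads level with each of the three groups measured before it: against 4-methoxyphenyl (a 1.3-fold higher number from compound 3 to compound 4 (0.12 log units; within the scatter)), against thiophen-2-yl (a 1.0-fold higher number from compound 2 to compound 4 (0.01 log units; within the scatter)) and against 4-chlorophenyl (a 1.1-fold lower number from compound 1 to compound 4 (0.04 log units; within the scatter)). This adds a new kind of comparison, as 5 heavy atoms enter where 8 leave in the step from 4-methoxyphenyl, yet the number stays within the scatter, so four aromatic groups on this double-bonded chain carbon now stand level, and neither ring size nor the kind of hetero atom separates them in these data. Nothing measured here explains why these groups read alike.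

Going by these compounds, all four groups are aromatic rings, so it remains open how this position would respond to a saturated ring such as cyclohexyl, a small chain such as methyl, or a ring carrying an amine or a carboxylic acid. On these data alone, it is also open whether any group at this place, or any change elsewhere on the shared core, could move the number beyond the scatter.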